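Compound 2 loses its fluoro

The source may report more compounds than this note shows. Statements on the series, on what has been measured and on what is new or still open speak of the compounds shown alone.

In a functional assay on A549 cells (Homo sapiens) for antiproliferative activity, read by sulforhodamine B assay, with a stated time of 48 h (a lower number here means a stronger inhibitor, a higher number a weaker inhibitor), compound 1 `COc1ccc(/C=C/C(=O)c2ccccc2-c2cccc(F)c2)cc1` gives 280 nM and compound 2 `COc1ccc(/C=C/C(=O)c2ccccc2-c2ccc(F)nc2)cc1` gives 930 nM as the higher of the two numbers. Compound 3 `COc1ccc(/C=C/C(=O)c2ccccc2-c2cccnc2)cc1` differs from compound 2 by hydrogen in place of fluoro on an aromatic carbon. Within the data shown here, the one measured step of a 3.3-fold higher number from compound 1 to compound 2 (0.52 log units; beyond the scatter) is modest, but it replaces 3-fluorophenyl with 6-fluoropyridin-3-yl and does not isolate the fluoro. Loss of the fluoro alone has not been measured, so no shift beyond the scatter is expected in this assay and neither direction is favoured. The expected 1.1-fold higher number from compound 2 to compound 3 (0.03 log units; within the scatter) is small. Compound 3 is estimated at 1000 nM with a range from 350 nM to 3000 nM for now.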

Compound 3, half-maximal inhibitory concentration: 580 nM
For compound 3 the middle estimate is 1.7-fold (0.24 log units) above the measured one; the range from low to high includes it.
By their numbers in this assay, from the lowest: compound 1; then compounds 3 and 2 (each within the scatter of the next).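

Taking away the fluoro alone gives, in this assay, a 1.6-fold lower number from compound 2 to compound 3 (0.21 log units; within the scatter), so this change on the carbon next to the ring nitrogen stays within the scatter. Pyridin-3-yl in place of 3-fluorophenyl gives a 2.1-fold higher number from compound 1 to compound 3 (0.32 log units; beyond the scatter), so a modest step beyond the scatter remains without the fluoro on the pyridine. No measured evidence bears on the cause of either step. Still open, as far as these compounds go, is whether an amine or a carboxylic acid on that same carbon would move the number beyond the scatter. Also open, from the compounds shown here alone, is how an unsubstituted phenyl would compare with 3-fluorophenyl.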